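The compounds below may be only part of what the source reports. "The series", "measured", "known", "first", "only" and "open" are said of these compounds alone.

Of the compounds shown here, two have been tested so far in a physicochemical assay for solubility, measured as kinetic solubility; on this read-out lower numbers stand for lower solubility and higher numbers for higher solubility. Compound 1 `COc1ccc(CNC(=O)c2nn(C)c3cccnc3c2=O)cc1` reads > 250000 nM, which is a limit of the assay and not a number. Compound 2 `O=C(NCc1ccc(F)cc1)c1ncc2c(N3CCCCS3(=O)=O)cccc2c1O` reads > 250000 nM, and this too is a limit of the assay. Together the two readings give only (the limit of > 250000 nM in this assay, at which 2 of the 2 values shown sit), so compound 2 offers no exact value as a starting point.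

Compound 3 `O=C(NCc1ccc(F)cc1)c1ncc2c(NC3CCOCC3)cccc2c1O` keeps the rest of compound 2 and changes one group: a group of 7 heavy atoms (5 carbon, 1 nitrogen, 1 oxygen; one six-membered non-aromatic ring with 1 hetero atom) in place of a group of 8 heavy atoms (4 carbon, 1 nitrogen, 2 oxygen, 1 sulfur; one six-membered non-aromatic ring with 2 hetero atoms), on an aromatic carbon. The (oxan-4-yl)amino group enters on an aromatic carbon of a six-membered aromatic ring of carbon only, replacing a group that also holds a six-membered non-aromatic ring.

Among the measured compounds shown here, no measured pair of compounds shows what such a swap does, so the expectation for this assay is cautious: a modest fall, or possibly no change beyond the usual scatter. The expected change is an at least 2.0-fold lower number from compound 2 to compound 3 (0.31 log units; beyond the scatter), and this size is only an estimate. The estimated value for compound 3 is 120000 nM, with an expected range from 30000 nM to 250000 nM.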

Compound 3, solubility: > 250000 nM
Compound 3: only a limit was reported; the forecaster's own chance of this, stated with the estimate: 40%; at least 2.0-fold (0.31 log units) between middle value and limit.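

In this assay compound 3 gives > 250000 nM, which is a limit of the assay and not a number. Among the compounds shown here, compound 2 also carries only a limit, and no step from compound 2 to compound 3 can be read. The compounds shown leave open how far the swap to the (oxan-4-yl)amino group moves the read-out, since every reading sits at one shared value: the limit of > 250000 nM in this assay, at which 3 of the 3 values shown sit.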